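A bromine added to a core that has shown no binding

This account rests on a few compounds, and the source may have more. Where it says the series, first, only, none or still open, it means among the compounds named here.

Measured so far:
Compound 1, `NS(=O)(=O)c1ccc(CNc2nc(Nc3cccc(NC(=O)N4CCCC4)c3)ncc2Br)cc1`, in an assay on HEK293 cells for displacement of a labelled ligand from MAP/microtubule affinity-regulating kinase 3 (Homo sapiens), read by NanoBRET (a higher number here means a weaker inhibitor, a lower number a stronger inhibitor), gives > 10000 nM, a limit of the assay rather than a number.
Compound 2, `O=C(NCCCNc1ccnc(Nc2cccc(NC(=O)N3CCCC3)c2)n1)C1CCC1`, in this assay gives > 10000 nM, again a limit rather than a number.

Among the measured compounds shown here, compound 2 therefore stands nowhere on a scale of numbers: for it only a limit is known, and the one further value shown is also a limit. For the measured compounds named here, both measured compounds sit at the limit of > 10000 nM in this assay, at which 2 of the 2 values shown sit, so no step between them can be sized.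

The unmeasured compound 3, `O=C(NCCCNc1nc(Nc2cccc(NC(=O)N3CCCC3)c2)ncc1Br)C1CCC1`, differs from compound 2 in one place: bromo in place of hydrogen on an aromatic carbon. The same bromo is present in compound 1, which also reached only the limit. Going by the values given here, with two limits and no measured step, no direction can be read from the data, and the expectation is that the change brings no difference beyond the scatter.

Compound 3 is expected to give 10000 nM, with a range from 3000 nM to 30000 nM. This expectation amounts to a step of a number no higher from compound 2 to compound 3 (the limit leaves the size open), with a high chance that only a limit is reported.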

Compound 3, half-maximal inhibitory concentration in the MAP/microtubule affinity-regulating kinase 3 assay: 137 nM
The estimate for compound 3 lay 73-fold (1.86 log units) above the measured number, and the stated range ends above it.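

In the MAP/microtubule affinity-regulating kinase 3 assay, bromo in place of hydrogen on this aromatic carbon lifts a compound off the limit of the assay and gives it a real number, a step of an at least 72-fold lower number from compound 2 to compound 3 (1.86 log units; beyond the scatter). Bromo alone is not enough, however, and the side chain counts as well: with bromo present on both sides, 2-((cyclobutylcarbonyl)amino)ethyl in place of 4-sulfamoylphenyl gives an at least 72-fold lower number from compound 1 to compound 3 (1.86 log units; beyond the scatter). Among these compounds, then, only the one that carries both the bromo and this chain gives a number. In a physicochemical assay for solubility, in phosphate buffer, measured as kinetic solubility, with a stated time of 24 h, at pH 7.4 (on this read-out lower numbers stand for lower solubility and higher numbers for higher solubility), compound 2 gives 136000 nM and compound 3 gives 177000 nM. In the physicochemical assay, the same bromo in place of hydrogen gives a 1.3-fold higher number from compound 2 to compound 3 (0.11 log units; within the scatter).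

In the MAP/microtubule affinity-regulating kinase 3 assay, compound 1 gives > 10000 nM, which is a limit of the assay. In the MAP/microtubule affinity-regulating kinase 3 assay, compound 2 gives > 10000 nM, which is also a limit. The true size of both binding steps stays open, as each starts from a limit and not from a number: the limit of > 10000 nM in the MAP/microtubule affinity-regulating kinase 3 assay, at which 2 of the 3 values shown sit.

Also open, from the compounds shown here alone, is whether chloro or methyl on this aromatic carbon, or a longer chain in place of 2-((cyclobutylcarbonyl)amino)ethyl, would give a number like that of compound 3.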